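Acetyl for bromophenyl on a thiourea: tolerance expected to rise

The compounds below may be only part of what the source reports. "The series", "measured", "known", "first", "only" and "open" are said of these compounds alone.

Compound 1, `FC(F)(F)c1cccc(NC(=S)Nc2cccc(Br)c2)c1`, is one of two thioureas measured so far. In an ADME assay on Vero 76 cells (Chlorocebus sabaeus) for cytotoxicity, read by crystal violet staining, with a stated time of 96 h (a lower number here means that less compound is tolerated, a higher number that more compound is tolerated), compound 1 gives 14000 nM, the lowest of the two numbers. Its nearest neighbour, compound 2, `Fc1ccc(NC(=S)Nc2cccc(C(F)(F)F)c2)cc1Cl`, gives 20000 nM in this assay; the two values lie within the scatter of each other, so no order between them can be stated. Compound 3, `CC(=O)NC(=S)Nc1cccc(C(F)(F)F)c1`, has not yet been measured. It differs from compound 1 in one place: acetyl in place of 3-bromophenyl on an amide-type nitrogen. Among the compounds with values here, no pair of measured compounds shows a step of this kind, so its size is not known from the data. The account nevertheless expects the number in this assay to move upward, a step of a 2.5-fold higher number from compound 1 to compound 3 (0.40 log units; beyond the scatter) that is expected to exceed the scatter. Compound 3 is estimated at 35000 nM, within a range from 12000 nM to 100000 nM, with some chance that only a limit is reported.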

Compound 3, half-maximal cytotoxic concentration: > 100000 nM
Compound 3 gave a limit, no number (the forecaster's own chance of this, stated with the estimate: 25%); at least 2.8-fold (0.45 log units) between middle value and limit.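

In this assay, acetyl in place of 3-bromophenyl on an amide-type nitrogen gives an at least 7.1-fold higher number from compound 1 to compound 3 (0.85 log units; beyond the scatter), so this position carries a change that moves the number past the scatter, which the earlier pair of compounds could not show. Compound 3 reads > 100000 nM, and this is a limit of the assay, not a number. The size of the step is therefore only a lower bound, because the reading stops at that limit: the limit of > 100000 nM in this assay, at which 1 of the 3 values shown sits.

The step swaps an aromatic ring for a carbonyl in a single move, and the compounds shown leave open which of the two carries it. Going by these compounds, whether a longer chain on the carbonyl, or an amine or a carboxylic acid at the end of such a chain, would keep the reading at the limit also remains open.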